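The source may hold more compounds than are shown below. What is called first, only, known or untested is meant among the compounds shown, and "the series" means these compounds.

The series shares one core; compound 1 `CC1(CC[C@H](c2ccc(C(=O)NCc3nn[nH]n3)cc2)N2C(=O)C(c3cc(Cl)cc(Cl)c3)=N[C@]23CC[C@@H](C(C)(C)C)CC3)CC1`, compound 2 `CC(C)(C)CC[C@H](c1ccc(C(=O)NCCC2=NNNN2)cc1)N1C(=O)C(c2cc(Cl)cc(Cl)c2)=N[C@]12CC[C@@H](C(C)(C)C)CC2` and compound 3 `CC(C)[C@H](c1ccc(C(=O)NCc2nn[nH]n2)cc1)N1C(=O)C(c2cc(Cl)cc(Cl)c2)=N[C@]12CC[C@@H](C(C)(C)C)CC2` have been measured in a functional assay on CHO cells for antagonist activity at Glucagon receptor (Homo sapiens), read by cAMP accumulation, with stated times of 30 min and 45 min; a lower number here means a stronger inhibitor, a higher number a weaker inhibitor. Compound 1 gives 100 nM, compound 2 gives 890 nM and compound 3 gives 2200 nM. Compound 2 stands second highest of the three numbers, nearest to compound 3 and furthest from compound 1, both gaps beyond the scatter. Within the data shown here, the only one-place step measured so far, a 22-fold higher number from compound 1 to compound 3 (1.34 log units; beyond the scatter), changes the saturated chain carbon bound to the amide-type nitrogen in a ring and the aromatic carbon, not the end of the amide chain, so it does not bear directly on the present change. Compound 4 `CC(C)(C)CC[C@H](c1ccc(C(=O)NCCS(=O)(=O)O)cc1)N1C(=O)C(c2cc(Cl)cc(Cl)c2)=N[C@]12CC[C@@H](C(C)(C)C)CC2` differs from compound 2 by a group of 4 heavy atoms (3 oxygen, 1 sulfur; no ring) in place of a group of 5 heavy atoms (1 carbon, 4 nitrogen; one five-membered non-aromatic ring with 4 hetero atoms), on a saturated chain carbon, two bonds along the chain from an amide-type nitrogen. Among the measured compounds shown here, no measured pair varies this group, so the direction is open; the sulfo group keeps a hydrogen-bond donor and acceptors, and a modest weakening is taken as the likelier outcome, with wide uncertainty. The step from compound 2 to compound 4 is expected at a 1.7-fold higher number from compound 2 to compound 4 (0.23 log units; within the scatter). Compound 4 is thus estimated at 1500 nM, within 400 nM to 6000 nM.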

Compound 4, half-maximal inhibitory concentration: 8500 nM
Compound 4: the middle estimate sits 5.7-fold (0.75 log units) below what was measured; the measured number lies above the stated range.
By their numbers in this assay, from the lowest: compound 1; then compound 2; then compound 3; then compound 4.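

In this assay, among these compounds, the step of a 9.6-fold higher number from compound 2 to compound 4 (0.98 log units; beyond the scatter) gives the first reading of this place, on a saturated chain carbon, two bonds along the chain from an amide-type nitrogen, and shows that the group carried there matters. Of this pair, compound 2, with the five-membered non-aromatic ring with 4 hetero atoms, is the stronger inhibitor, and sulfo does not stand in for that ring at equal strength. No measured evidence is available to explain this step.

From the compounds shown here alone, whether a carboxylic acid or a primary amine at this place would fall nearer compound 2 or compound 4 remains open. Also open, going by these compounds, is whether the same exchange would give a step of similar size with the isopropyl of compound 3 or the 2-(1-methylcyclopropyl)ethyl of compound 1 on the saturated chain carbon.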